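Compound 1 to its methoxycarbonyl analogue

This account rests on a few compounds, and the source may have more. Where it says the series, first, only, none or still open, it means among the compounds named here.

Measured in a functional assay (blood) for inhibition, with Homo sapiens as the target; on this read-out lower numbers stand for stronger inhibition and higher numbers for weaker inhibition:
- compound 1 `CC(O)c1cc(-c2ccccc2)c2ccc(OCc3cccc(C4(O)CCOCC4)c3)cc2c1`: 675 nM
- compound 2 `COC(C)c1cc(-c2ccccc2)c2ccc(OCc3cccc(C4(O)CCOCC4)c3)cc2c1`: > 1000 nM (a limit of the assay)

Among the compounds with values here, compound 1 holds the only actual number, since compound 2 gives only a limit. Compound 3 `COC(=O)c1cc(-c2ccccc2)c2ccc(OCc3cccc(C4(O)CCOCC4)c3)cc2c1` carries methoxycarbonyl in place of 1-hydroxyethyl on an aromatic carbon, with methoxycarbonyl in place of 1-hydroxyethyl on an aromatic carbon. Within the data shown here, the one measured step that bears on it is an at least 1.4-fold higher number from compound 1 to compound 2 (0.17 log units; that floor lies within the scatter), which also removes the hydroxyl hydrogen. A modest step towards weaker inhibition is therefore expected, estimated as a 1.3-fold higher number from compound 1 to compound 3 (0.12 log units; within the scatter). For compound 3 the estimate is 900 nM, with an expected range of 300 nM to 2500 nM.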

Compound 3, half-maximal inhibitory concentration: 100 nM
Compound 3: the middle estimate sits 9.0-fold (0.95 log units) above what was measured; the measured number lies below the stated range.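

In this assay, methoxycarbonyl in place of 1-hydroxyethyl gives a 6.8-fold lower number from compound 1 to compound 3 (0.83 log units; beyond the scatter), so a lower number at this position does not need the hydrogen-bond donor of 1-hydroxyethyl. Methoxycarbonyl in place of 1-methoxyethyl gives an at least 10-fold lower number from compound 2 to compound 3 (1.00 log units; beyond the scatter). That step starts from compound 2, whose value is a limit and not a number: the limit of > 1000 nM in this assay, at which 1 of the 3 values shown sits.

The compounds shown do not separate the part played by the carbonyl from that of the ester methyl. A carboxylic acid, a primary amide or an acetyl group at this position would bear on that question.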